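The source may hold more compounds than are shown below. What is called first, only, known or untested is meant among the compounds shown, and "the series" means these compounds.

Measured so far:
- Compound 1, `CCCCc1cc2ccccc2nc1-c1cc(-c2ccc(F)cc2)no1`, in a functional assay on A549 cells (Homo sapiens) for inhibition, read by MTT assay, with a stated time of 24 h (a lower number here means a stronger inhibitor, a higher number a weaker inhibitor), gives 27500 nM.
- Compound 2, `CCCc1cc2ccccc2nc1-c1cc(-c2ccc(C)cc2)no1`, in this assay gives > 100000 nM, which is a limit of the assay rather than a number.

Compound 2 therefore stands at the weak end of what has been measured: its result is only a limit, as the limit of > 100000 nM in this assay, at which 1 of the 2 values shown sits, records, so its true potency is not pinned down. Compound 3, `CCCCc1cc2ccccc2nc1-c1cc(-c2ccc(C)cc2)no1`, differs from compound 2 by methyl in place of hydrogen on a saturated chain carbon, three bonds along the chain from an aromatic carbon; in plain words, the propyl chain becomes a butyl chain. Within the data shown here, compound 1 also carries a butyl chain and gives a measurable value, but it differs from compound 3 elsewhere as well, so no step in this assay can be read from it. The step from compound 2 to compound 3 is expected to be modest, if any, and is estimated at an at least 1.6-fold lower number from compound 2 to compound 3 (0.22 log units; that floor lies within the scatter). Compound 3 is expected to give about 60000 nM, within a range of 20000 nM to 200000 nM.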

Compound 3, half-maximal inhibitory concentration: > 100000 nM
Compound 3 ended at the assay's limit; the forecaster's own chance of this, stated with the estimate: 50%; at least 1.6-fold (0.22 log units) between middle value and limit.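

Extending the propyl chain to a butyl chain at this position does not bring the result away from the limit: in this assay compound 3 gives > 100000 nM as a limit and not a number. With the butyl chain shared, methyl in place of fluoro on an aromatic carbon gives a readable change, an at least 3.6-fold higher number from compound 1 to compound 3 (0.56 log units; beyond the scatter) in this comparison. The step for the chain change cannot be read, as both of its ends are limits: the limit of > 100000 nM in this assay, at which 2 of the 3 values shown sit.

As far as these compounds go, whether the chain length matters at all therefore remains open, and a pentyl chain in this place might or might not give a measurable value. Also open, from the compounds shown here alone, is whether another group on that aromatic carbon, such as chloro or methoxy, would behave like fluoro or like methyl.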